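From propyl to 4-chlorophenyl on a shared core

The source may report more compounds than this note shows. Statements on the series, on what has been measured and on what is new or still open speak of the compounds shown alone.

In a functional assay on HCT-116 cells (Homo sapiens) for antiproliferative activity, read by MTT assay, with a stated time of 72 h (on this read-out higher numbers stand for weaker inhibition and lower numbers for stronger inhibition), compound 1 (`O=C(Nc1ccc(Nc2nccc(NC3CCCCC3)n2)cc1)Nc1ccc(Cl)c(C(F)(F)F)c1`) reads 5950 nM and compound 2 (`CCCNc1ccnc(Nc2ccc(NC(=O)Nc3ccc(Cl)c(C(F)(F)F)c3)cc2)n1`) reads 4240 nM and these two values sit level within the usual scatter. Compound 3 (`O=C(Nc1ccc(Nc2nccc(Nc3ccc(Cl)cc3)n2)cc1)Nc1ccc(Cl)c(C(F)(F)F)c1`) has not yet been measured. It differs from compound 2 in one place, with 4-chlorophenyl in place of propyl on a nitrogen on an aromatic ring. Among the measured compounds shown here, only one measured step bears on this change: a 1.4-fold lower number from compound 1 to compound 2 (0.15 log units; within the scatter) for propyl in place of cyclohexyl on that nitrogen, and it stays within the scatter. For the measured compounds named here, no measured compound carries an aromatic ring there, so the data suggest no direction. The estimated step is a 1.4-fold lower number from compound 2 to compound 3 (0.15 log units; within the scatter) and nothing beyond the scatter is expected. The estimate for compound 3 is 3000 nM in this assay with an expected range from 900 nM to 10000 nM given how little is known.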

Compound 3, half-maximal inhibitory concentration: 4660 nM
Estimate against measurement, compound 3: 1.6-fold (0.19 log units) below; the range from low to high includes it.
By their numbers in this assay, from the lowest: compounds 2, 3 and 1 (each within the scatter of the next).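

Among the compounds shown here, with 4-chlorophenyl, an aromatic ring now sits on the nitrogen for the first time, and in this assay the reading stays level with both earlier compounds, showing a 1.1-fold higher number from compound 2 to compound 3 (0.04 log units; within the scatter) and a 1.3-fold lower number from compound 1 to compound 3 (0.11 log units; within the scatter) as well. The earlier pair compared only a propyl chain with a cyclohexyl ring, whereas these three compounds show that a chain, a saturated ring and a chlorinated aromatic ring all sit within the scatter of one another at this position. No measurement at hand explains why these readings sit level.

From the compounds shown here alone, whether a longer chain carrying an amine or a carboxylic acid at this nitrogen would shift the reading beyond the scatter remains open. Also open, going by these compounds, is whether an aromatic ring without the chlorine would read level with these three compounds.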